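Hydroxyalkyl side chain variants at the cytotoxicity limit

A few compounds are considered here, and "the series" means these few. Any claim that something is new, unique, unknown or untested is made for them only; others in the source may bear on it.

Cytotoxicity across the series was read in an ADME assay on HEp-2 cells (Homo sapiens) for cytotoxicity, with a stated time of 4 days; on this read-out higher numbers stand for lower toxicity in this test and lower numbers for higher toxicity in this test. Compound 1 `CS(=O)(=O)c1nn(Cc2nc3cc(Cl)ccc3n2CCCCO)c2cnccc12` carries a 3-hydroxypropyl chain on the aromatic nitrogen. In this assay compound 1 returns only the limit > 100000 nM, not a number. Compound 2 `CC(C)(CO)Cn1c(Cn2nc(S(C)(=O)=O)c3ccncc32)nc2cc(Cl)ccc21` bears 1-(hydroxymethyl)-1-methylethyl in place of 3-hydroxypropyl on a saturated chain carbon bound to an aromatic nitrogen. In this assay compound 2 likewise reaches only the limit > 100000 nM. Compound 3 `CS(=O)(=O)c1nn(Cc2nc3cc(Cl)ccc3n2CCOCCO)c2cnccc12` has 2-hydroxyethoxy in place of 2-hydroxyethyl on a saturated chain carbon, two bonds along the chain from an aromatic nitrogen. In this assay compound 3 also gives only the limit > 100000 nM. Every value shown sits at the limit of > 100000 nM in this assay, at which 3 of the 3 values shown sit, so the steps among the three remain unreadable: a step that the two limits leave unreadable from compound 1 to compound 2, a step that the two limits leave unreadable from compound 1 to compound 3 and a step that the two limits leave unreadable from compound 2 to compound 3. Compound 3 thus stands at the limit with the other two, and no order among them can be stated.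

Compound 4 `CS(=O)(=O)c1nn(Cc2nc3cc(Cl)ccc3n2CCC(O)C(F)(F)F)c2cnccc12` changes the same chain region: 2,2,2-trifluoro-1-hydroxyethyl in place of 2-hydroxyethoxy on a saturated chain carbon, two bonds along the chain from an aromatic nitrogen. All three measured steps bear on this change, and none of them has a readable size. The expected step is a number no higher from compound 3 to compound 4 (the limit leaves the size open), none beyond the scatter. Compound 4 is expected at 100000 nM, within 30000 nM to 300000 nM, most probably again as a limit.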

Compound 4, half-maximal cytotoxic concentration: > 100000 nM
Compound 4: a limit, no number; the forecaster's own chance of this, stated with the estimate: 80%; the middle value sits exactly at the limit.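

In this assay compound 4 returns > 100000 nM, a limit and not a number. Within the data shown here, no step from compound 1, compound 2 or compound 3 to compound 4 can be read, and the series stays at one value: the limit of > 100000 nM in this assay, at which 4 of the 4 values shown sit. The compounds shown leave open whether these side chains differ in cytotoxicity at all; none gives a number.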